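The source may hold more compounds than are shown below. What is called first, only, known or untested is meant among the compounds shown, and "the series" means these compounds.

Compound 1 `Cc1c(F)c(N)c2c(=O)cc(-c3ccc(N)c(F)c3)oc2c1F` is the starting point of this step. Among the compounds with values here, in a functional assay on MCF7 cells (Homo sapiens) for cytotoxicity, read by neutral red uptake, with a stated time of 3 days (on this read-out lower numbers stand for stronger inhibition and higher numbers for weaker inhibition), compound 1 gives 13 nM, the higher of the two numbers measured so far. Within the data shown here, its only measured neighbour is compound 2 `Nc1ccc(-c2cc(=O)c3c(N)c(F)c(N)c(F)c3o2)cc1F`, which in this assay gives 7.7 nM; the step of a 1.7-fold lower number from compound 1 to compound 2 (0.23 log units; within the scatter) is a change of amino in place of methyl on an aromatic carbon.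

Compound 3 `CN(C)CCCC(=O)OCc1c(F)c(N)c2c(=O)cc(-c3ccc(N)c(F)c3)oc2c1F` has not been measured. It differs from compound 1 by ((3-(dimethylamino)propyl)carbonyl)oxy in place of hydrogen on a saturated chain carbon bound to an aromatic carbon. The group enters on the same methyl carbon that compound 2 replaces entirely, yet compound 2 removes that carbon rather than extending it, so the step from compound 1 to compound 2 does not speak to the change at hand. Among the measured compounds shown here, no measured step adds a chain of this kind to the shared core of compound 1, and the only step known, a 1.7-fold lower number from compound 1 to compound 2 (0.23 log units; within the scatter), lies within the scatter. The number for compound 3 in this assay is therefore expected to move by a 2.3-fold higher number from compound 1 to compound 3 (0.36 log units; beyond the scatter), toward a weaker reading, with a wide range. Compound 3 is estimated at 30 nM in this assay, between 8 nM and 120 nM.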

Compound 3, half-maximal inhibitory concentration: 29 nM
Compound 3: middle estimate off by 1.0-fold (0.01 log units), on the high side, and the stated range covers the measured number.
By their numbers in this assay, from the lowest: compounds 2 and 1 (each within the scatter of the next); then compound 3.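

Within the data shown here, the saturated chain carbon bound to an aromatic carbon in compound 1 accepts the ((3-(dimethylamino)propyl)carbonyl)oxy group, and this assay records a 2.2-fold higher number from compound 1 to compound 3 (0.35 log units; beyond the scatter) as the first step to lie beyond the scatter, though it remains modest. Set against compound 2, the (((3-(dimethylamino)propyl)carbonyl)oxy)methyl group in place of amino on an aromatic carbon gives a 3.8-fold higher number from compound 2 to compound 3 (0.58 log units; beyond the scatter) as a somewhat wider but still modest gap, so this position carries a chain of this kind with a measurable shift toward weaker inhibition and without loss of the reading. Nothing measured here accounts for the shift.

The compounds shown leave open whether the shift belongs to the ester link or to the dimethylamino end of the chain, and whether an amide link, a hydroxymethyl group or a longer chain on the same carbon would read alike. Going by these compounds, they also show this change in only one cell line and by only one read-out, so its behaviour in other cells remains open.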